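The compounds below may be only part of what the source reports. "The series", "measured", "known", "first", "only" and "open" are said of these compounds alone.

Compound 1 `ClCc1ccc(Cn2cnc3c(Cl)ncnc32)cc1` is the point of departure. In a functional assay on SNB-75 cells (Homo sapiens) for cytotoxicity, read by sulforhodamine B assay, with a stated time of 48 h (on this read-out lower numbers stand for higher toxicity in this test and higher numbers for lower toxicity in this test), compound 1 stands without a number: the recorded outcome is "not determined" (no result reported), so nothing can be said of where it lies. Two related compounds carry numbers. Going by the values given here, compound 2 `Nc1nc(Cl)c2ncn(Cc3ccccc3CCl)c2n1` gives 64600 nM in this assay, and compound 3 `ClCc1cccc(Cn2cnc3nc(Cl)nc(Cl)c32)c1` gives 4780 nM in this assay; the two values lie far apart, but no step links them here and no step links either to compound 1. The change that leads onward is chloro in place of hydrogen on an aromatic carbon, placed on the shared core of compound 1, giving compound 4 `ClCc1ccc(Cn2cnc3c(Cl)nc(Cl)nc32)cc1`. Among the compounds with values here, with no number for compound 1, no step in this assay can be expected in a direction or size; only a level can be guessed. Compound 4 resembles compound 3 most closely among the measured compounds, and on that footing compound 4 is expected to give about 6500 nM in this assay, with a likely range from 2000 nM to 25000 nM.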

Compound 4, concentration lethal to 50% of the cells: 45700 nM
Compound 4: the middle estimate sits 7.0-fold (0.85 log units) below what was measured, outside the stated range (above it).
By their numbers in this assay, from the lowest: compound 3; then compounds 4 and 2 (each within the scatter of the next).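

In this assay, going by these compounds alone, compound 1 has no number, so no step from compound 1 to compound 4 can be read. The compounds shown leave open how chloro in place of hydrogen shifts the read-out on the shared core. Nothing shown explains the result for compound 4.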